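Adding a nitrile to compound 2: a small expected shift

The source may hold more compounds than are shown below. What is called first, only, known or untested is meant among the compounds shown, and "the series" means these compounds.

Of the compounds shown here, two have been measured in a functional assay on A549 cells (Homo sapiens) for inhibition, tested at 0.1 uM; on this read-out higher numbers stand for a stronger effect at the one concentration tested and lower numbers for a weaker effect. Compound 1 has the structure `COc1ccc2c(-c3cc(C(F)(F)F)c(C#N)c(-c4cn(S(=O)(=O)c5ccc(C)cc5)c5cc(OC)ccc45)n3)cn(S(=O)(=O)c3ccc(C)cc3)c2c1` and in this assay compound 1 gives 33%. Compound 2 has the structure `Cc1ccc(S(=O)(=O)n2cc(-c3cc(C(F)(F)F)cc(-c4cn(S(=O)(=O)c5ccc(C)cc5)c5cc(Br)ccc45)n3)c3ccc(Br)cc32)cc1` and in this assay compound 2 gives 25.8%. Compound 2 has the lower of the two numbers, yet the gap to compound 1 lies within the scatter, so the two cannot be told apart.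

Compound 3 has the structure `Cc1ccc(S(=O)(=O)n2cc(-c3cc(C(F)(F)F)c(C#N)c(-c4cn(S(=O)(=O)c5ccc(C)cc5)c5cc(Br)ccc45)n3)c3ccc(Br)cc32)cc1`. It differs from compound 2 in one place: cyano in place of hydrogen on an aromatic carbon. Compound 1 also carries a cyano group and its value stands close to that of compound 2, so no large change is expected here. The step from compound 2 to compound 3 is estimated as a number 4.2 percentage points higher from compound 2 to compound 3 (within the scatter), a shift not beyond the scatter. For compound 3 the expected result is 30%, in a range from 15% to 45%.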

Compound 3, a percentage reported as inhibition, at one concentration (the size of the read-out at that concentration, not a potency): 23.8%
Compound 3: middle estimate off by 6.2 percentage points, on the high side, and the stated range covers the measured number.
By their numbers in this assay, from the lowest: compounds 3, 2 and 1 (each within the scatter of the next).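

For the compounds shown here, replacing hydrogen with cyano on this aromatic carbon, which is ortho to a trifluoromethyl group and two atoms from the ring nitrogen, gives the first one-place comparison in this assay, with a number 2 percentage points lower from compound 2 to compound 3 (within the scatter) as the result. On this core, then, the cyano group at this position produces no change that can be told apart from the scatter of repeated measurements at the one concentration tested. No measurement at hand bears on why the number stays where it is.

From the compounds shown here alone, whether an amine, a carboxylic acid or a longer chain on this same aromatic carbon would shift the number beyond the scatter remains open. Also open, going by these compounds, is whether cyano would give a stronger or weaker effect at other concentrations.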